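Swapping pyrrolidin-1-yl for pyridin-4-yl on a carbonyl carbon

This account rests on a few compounds, and the source may have more. Where it says the series, first, only, none or still open, it means among the compounds named here.

Values so far in a physicochemical assay for solubility, read by HPLC, with a stated time of 24 h (on this read-out lower numbers stand for lower solubility and higher numbers for higher solubility), for two compounds
Compound 1 `CC(C)(C)c1[nH]cnc1/C=c1\[nH]c(=O)/c(=C/c2cccc(C(=O)N3CCCC3)c2)[nH]c1=O` gives 0.454 ug/mL
Compound 2 `O=C(c1cccc(/C=c2\[nH]c(=O)/c(=C/c3ccccn3)[nH]c2=O)c1)N1CCC1` gives 0.662 ug/mL

Repeat measurements of this kind never agree exactly, so two close numbers need not mean a real difference. Compound 1 and compound 2 lie within the usual scatter of each other in this assay and the numbers give them no order. Among the compounds with values here, compound 1 therefore stands level with the only other measured compound.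

Compound 3 `CC(C)(C)c1[nH]cnc1/C=c1\[nH]c(=O)/c(=C/c2cccc(C(=O)c3ccncc3)c2)[nH]c1=O` keeps the core of compound 1 and differs in one place. On a carbonyl carbon, pyridin-4-yl stands in place of pyrrolidin-1-yl (pyridin-4-yl in place of pyrrolidin-1-yl on a carbonyl carbon). Within the data shown here, no two measured compounds differ in just one place, so the data show nothing directly about this change. The expected step of a 1.1-fold lower number from compound 1 to compound 3 (0.05 log units; within the scatter) is therefore none beyond the scatter, with no direction favoured. This expectation leans on compound 1 at 0.454 ug/mL as the closest measured structure. For compound 3 the estimated value is 0.4 ug/mL with an expected range from 0.13 ug/mL to 1.2 ug/mL in this assay once it is measured.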

Compound 3, solubility: < 0.1 ug/mL
Compound 3 ended at the assay's limit; the forecaster's own chance of this, stated with the estimate: 10%; middle value at least 4.0-fold (0.60 log units) away from the limit.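

In this assay, the value of compound 3 is a limit of the assay and not a number: the limit of < 0.1 ug/mL in this assay, at which 1 of the 3 values shown sits.

Even with that limit, the change can be read, and pyridin-4-yl in place of pyrrolidin-1-yl on a carbonyl carbon gives an at least 4.5-fold lower number from compound 1 to compound 3 (0.65 log units; beyond the scatter). The earlier compounds shown here could not show this, since compound 1 and compound 2 differ in more than one place and their values gave them no order. This pair now shows that the group on this carbonyl carbon can move the solubility read-out beyond the scatter, and that the change lowers the number on the core of compound 1.

From the compounds shown here alone, what remains open is how far this one step reaches, since it rests on a single pair with a single core, and the limit leaves its full size unknown. Other groups on the same carbonyl carbon, such as a morpholine ring, an open-chain dimethylamino group or a piperazine ring, would show whether the number depends on the ring being aromatic or on something else that sets these two groups apart.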